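Acetyl to dimethylamino on the pendant phenyl ring

The source may hold more compounds than are shown below. What is called first, only, known or untested is meant among the compounds shown, and "the series" means these compounds.

Measured in a functional assay on ACHN cells (Homo sapiens) for cytotoxicity, read by sulforhodamine B assay, with a stated time of 48 h, tested at 0.001 uM; a higher number here means a weaker effect of the compound at the concentration tested, a lower number a stronger effect:
compound 1 `COc1cc(C)cc(-c2c(-c3ccnc(-c4ccc(C(C)=O)cc4)c3)cnn2CC#N)c1` gives 100%
compound 2 `Cc1cc(O)cc(-c2nn(CC#N)cc2-c2ccnc(-c3ccc(Oc4ccccc4)cc3)c2)c1` gives 98%

Both readings sit at the level of essentially no effect at the concentration tested. Compound 1 and compound 2 lie within the scatter of each other, so neither can be separated from the other on these two numbers; compound 1 simply stands with the larger figure of the pair without that meaning anything.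

Compound 3 `COc1cc(C)cc(-c2c(-c3ccnc(-c4ccc(N(C)C)cc4)c3)cnn2CC#N)c1` is the next member, not yet measured in this assay. It differs from compound 1 in one place: dimethylamino in place of acetyl on an aromatic carbon. The shared core, the nitrile-bearing side chain and the methoxy-methyl-substituted ring are unchanged.

Among the measured compounds shown here, with no step between measured compounds to lean on, the expectation for compound 3 rests on compound 1, which already gives 100% in this assay. The expected step of a number 1 percentage points lower from compound 1 to compound 3 (within the scatter) is none beyond the scatter. Compound 3 is therefore estimated at 99%, with a range from 89% to 106%.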

Compound 3, a percentage reported as activity, at one concentration (the size of the read-out at that concentration, not a potency): 98%
For compound 3 the middle estimate is 1 percentage points above the measured one; the range from low to high includes it.
By their numbers in this assay, from the lowest: compounds 2, 3 and 1 (each within the scatter of the next).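

Replacing acetyl with dimethylamino on the aromatic carbon para to a large group gives a number 2 percentage points lower from compound 1 to compound 3 (within the scatter) in this assay, with the shared core, the nitrile-bearing side chain and the methoxy-methyl-substituted ring held constant. Among the compounds shown here, this is the first comparison that differs in one place, and it shows that the 4-acetylphenyl and 4-(dimethylamino)phenyl compounds cannot be told apart at this single concentration, where both remain at the level of essentially no effect. No measured information is available to explain this reading of the pair.

For the compounds shown here, the single pair does not show whether this position is insensitive in general or whether the concentration tested is simply too low to reveal any difference between compounds, as a reading near the level of no effect cannot rank them. A carboxylic acid, a morpholine ring or a longer alkyl chain in place of acetyl at the same position, together with readings at higher concentrations, would be needed to settle how much this part of the molecule matters for cytotoxicity on these cells.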